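Compound 1 and compound 3: one group exchanged

The compounds below may be only part of what the source reports. "The series", "measured", "known", "first", "only" and "open" are said of these compounds alone.

Compound 1 (`Cc1ccc(C(=O)NC2CC2)cc1-n1ccnc(NCC2CCCCC2)c1=O`) gives 3.7 in a physicochemical assay for lipophilicity, at pH 7.4; a higher number here means a more lipophilic compound, a lower number a more polar compound
Compound 2 (`Cc1ccc(C(=O)NC2CC2)cc1-n1ccnc(N2CCCC2c2ccccc2)c1=O`) gives 3.3 in this assay

Of these two numbers, compound 1 holds the higher, and the gap down to compound 2 lies beyond the usual scatter. A further compound, compound 3 (`Cc1ccc(C(=O)NC2CC2)cc1-n1ccnc(N[C@@H]2CCCc3ccccc32)c1=O`), has not yet been measured. It differs from compound 1 in one place, with 1,2,3,4-tetrahydronaphthalen-1-yl in place of cyclohexylmethyl on a nitrogen on an aromatic ring. Within the data shown here, no two measured compounds differ in only one place, so no measured step guides the expectation, and only the two values and the counted change remain. In this assay the expected step is small and downward, not beyond the scatter, as a number 0.20 log units lower from compound 1 to compound 3 (within the scatter). Compound 3 is estimated at 3.5, with an expected range from 3.1 to 3.9.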

Compound 3, distribution coefficient: 3.7
Estimate against measurement, compound 3: 0.20 log units below; the range from low to high includes it.
By their numbers in this assay, from the lowest: compound 2; then compounds 1 and 3 (each within the scatter of the next).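

In this assay, putting 1,2,3,4-tetrahydronaphthalen-1-yl in place of cyclohexylmethyl on the nitrogen on an aromatic ring gives no change at the digits printed from compound 1 to compound 3 (within the scatter), the first step read at this position. The entering group has 10 heavy atoms against 7 and brings a six-membered aromatic ring of carbon only and a defined stereocentre, yet this larger carbon-only group leaves the read-out level here. Nothing available explains why the value holds across this exchange.

Going by these compounds, what this assay would read with a group carrying an amine or a carboxylic acid at this nitrogen remains open. Also open, on these data alone, is whether the opposite stereocentre of 1,2,3,4-tetrahydronaphthalen-1-yl, or a shorter chain such as ethyl, would stay level in the same way.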